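Adding a second carbonyl group to compound 2

The compounds below may be only part of what the source reports. "The series", "measured", "known", "first", "only" and "open" are said of these compounds alone.

Compound 1 `N[C@@H](CC(=O)OC[C@H]1O[C@@H](n2cc(F)c(=O)[nH]c2=O)C[C@@H]1O)C(=O)O`: 2.5 h
Compound 2 `CC(C)[C@H](N)C(=O)OC[C@H]1O[C@@H](n2cc(F)c(=O)[nH]c2=O)C[C@@H]1O`: 1.31 h

Among the compounds with values here, in an ADME assay on a cell-free system (plasma, Rattus norvegicus) for metabolic stability, read by LC-MS, with a stated time of 120 min, tested at 200 uM (on this read-out lower numbers stand for a shorter-lived compound and higher numbers for a longer-lived compound), compound 2 gives 1.31 h, one of only two measured values, and it lies within the scatter of compound 1 at 2.5 h. The compound awaiting measurement is compound 3 `CC(C)[C@H](N)C(=O)OC[C@H]1O[C@@H](n2cc(F)c(=O)[nH]c2=O)C[C@@H]1OC(=O)[C@@H](N)C(C)C`. Its structure departs from that of compound 2 in one place: (1-amino-2-methylpropyl)carbonyl in place of hydrogen on an oxygen on a saturated carbon. In words, (1-amino-2-methylpropyl)carbonyl stands in place of hydrogen on an oxygen on a saturated carbon, so a hydroxy becomes ((1-amino-2-methylpropyl)carbonyl)oxy.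

Within the data shown here, only one measured step offers any guide, and only loosely: a 1.9-fold lower number from compound 1 to compound 2 (0.28 log units; within the scatter). That step exchanges one group for another on a carbonyl carbon and stays within the scatter. Among the measured compounds shown here, no measured step adds a group on this oxygen, so the data give no direct size for the change. A small drop is assumed, with no shift beyond the scatter expected. The estimated step is a 1.3-fold lower number from compound 2 to compound 3 (0.12 log units; within the scatter), a deliberately cautious expectation. Compound 3 is expected at about 1 h, with an estimated range of 0.4 h to 2.2 h.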

Compound 3, half-life: 0.63 h
Compound 3: middle estimate off by 1.6-fold (0.20 log units), on the high side; the range from low to high includes it.
By their numbers in this assay, from the lowest: compound 3; then compounds 2 and 1 (each within the scatter of the next).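

In this assay, exchanging hydrogen for (1-amino-2-methylpropyl)carbonyl on the oxygen on a saturated carbon, so that a hydroxy becomes ((1-amino-2-methylpropyl)carbonyl)oxy, gives a 2.1-fold lower number from compound 2 to compound 3 (0.32 log units; beyond the scatter). Within the data shown here, this is the first reading of a change at this oxygen, and the first step to pass beyond the scatter, though only modestly; the earlier exchange on a carbonyl carbon, a 1.9-fold lower number from compound 1 to compound 2 (0.28 log units; within the scatter), had stayed within it. The free hydroxy therefore emerges as a place where a change can move the half-life, and compound 3 now carries the same acyl group at both sites, yet no available evidence accounts for the lower number.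

As far as these compounds go, what remains open is whether this shift belongs to the (1-amino-2-methylpropyl)carbonyl group itself or would follow from any acyl group on this oxygen, such as a simple acetyl or a longer unbranched acyl chain. The compounds shown also leave unresolved how the 2-amino-2-carboxyethyl carbonyl group of compound 1 would behave at this oxygen, or how a methyl ether there would compare.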